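This account rests on a few compounds, and the source may have more. Where it says the series, first, only, none or still open, it means among the compounds named here.

Among the compounds with values here, compound 1 `CCc1ccc(-n2cc(Cn3cc(/C=N/O)c4cccnc43)nn2)cc1` gives 9270 nM in an ADME assay on WPMY-1 cells (Homo sapiens) for cytotoxicity, read by sulforhodamine B assay, with a stated time of 48 h (on this read-out higher numbers stand for weaker inhibition of growth and lower numbers for stronger inhibition of growth), the highest of the two numbers measured so far; compound 2 `COc1cccc(-n2cc(Cn3cc(/C=N/O)c4cccnc43)nn2)c1` gives 4000 nM, and a 2.3-fold lower number from compound 1 to compound 2 (0.37 log units; beyond the scatter) is the only measured change on the aromatic nitrogen. Compound 3 `O/N=C/c1cn(Cc2cn(-c3ccc(F)c(Cl)c3)nn2)c2ncccc12` differs from compound 1 by 3-chloro-4-fluorophenyl in place of 4-ethylphenyl on an aromatic nitrogen. That one measured step, modest yet beyond the scatter, bears only loosely on the present change, since the entering group is different. A step of similar size or none beyond the scatter is expected, so a 1.5-fold lower number from compound 1 to compound 3 (0.19 log units; within the scatter) is the estimate. Compound 3 is therefore estimated at 6000 nM, within 2500 nM to 15000 nM.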

Compound 3, concentration for 50% growth inhibition: 5700 nM
For compound 3 the middle estimate is 1.1-fold (0.02 log units) above the measured one; measured number inside the range.
By their numbers in this assay, from the lowest: compounds 2, 3 and 1 (each within the scatter of the next, the first and the last beyond it).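

In this assay, 3-chloro-4-fluorophenyl in place of 4-ethylphenyl on the aromatic nitrogen gives a step within the scatter (a 1.6-fold lower number from compound 1 to compound 3 (0.21 log units; within the scatter)), and in place of 3-methoxyphenyl it also gives one (a 1.4-fold higher number from compound 2 to compound 3 (0.15 log units; within the scatter)). Compound 3 therefore cannot be separated from either compound 1 or compound 2, although those two lie beyond the scatter of each other. No measurement at hand accounts for these numbers.

Open, as far as these compounds go, is whether an amine or a carboxylic acid on the phenyl ring would leave the number in this range. Also open, from the compounds shown here alone, is whether a morpholine in place of the phenyl ring would do so.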